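Cyclopropyl on the amide nitrogen of compound 1

The compounds below may be only part of what the source reports. "The series", "measured", "known", "first", "only" and "open" are said of these compounds alone.

Measured in a functional assay on the whole organism with Mus musculus as the target; on this read-out higher numbers stand for an effect only at larger amounts of compound and lower numbers for an effect already at smaller amounts:
- compound 1 `NC(=O)/C=C1\CCc2c(F)cccc21`: > 100 mg/kg, a limit and not a number
- compound 2 `CN(C)C(=O)/C=C1\CCc2c(F)cc(F)cc21`: 50 mg/kg
- compound 3 `NC(=O)/C=C1\CCc2c(F)cc(F)cc21`: 69 mg/kg

Compound 1 stands at the limit of > 100 mg/kg in this assay, at which 1 of the 3 values shown sits. Within the data shown here, its one measured step, fluoro in place of hydrogen on an aromatic carbon, is an at least 1.4-fold lower number from compound 1 to compound 3 (0.16 log units; that floor lies within the scatter).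

Compound 4 `O=C(/C=C1\CCc2c(F)cccc21)NC1CC1` carries cyclopropyl in place of hydrogen on an amide-type nitrogen. Among the measured compounds shown here, the only measured change on that nitrogen, amino in place of dimethylamino on a carbonyl carbon, gives a 1.4-fold higher number from compound 2 to compound 3 (0.14 log units; within the scatter), so no step beyond the scatter is expected in this assay. The estimated step is a step that the limit leaves unreadable from compound 1 to compound 4. For compound 4 the expected value is 110 mg/kg, with an estimated range of 50 mg/kg to 240 mg/kg.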

Compound 4, dose for half-maximal effect: 126 mg/kg
For compound 4 the middle estimate is 1.1-fold (0.06 log units) below the measured one; the range from low to high includes it.
By their numbers in this assay, from the lowest: compounds 2, 3 and 4 (each within the scatter of the next, the first and the last beyond it).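

No step from compound 1 to compound 4 can be read, because the value of compound 1 is a limit and not a number: the limit of > 100 mg/kg in this assay, at which 1 of the 4 values shown sits.

The compounds shown leave open whether cyclopropyl in place of hydrogen on an amide-type nitrogen changes the dose needed at all.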